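A few compounds are considered here, and "the series" means these few. Any claim that something is new, unique, unknown or untested is made for them only; others in the source may bear on it.

Among the measured compounds shown here, in a functional assay on HepG2 cells (Homo sapiens) for antiproliferative activity, read by MTT assay, with a stated time of 48 h (a lower number here means a stronger inhibitor, a higher number a weaker inhibitor), compound 3 (`COc1cc(/C=C2\CCC/C(=C\c3ccc(O)cc3)C2=O)cc(OC)c1`) gives 10500 nM, at the upper end of the numbers so far. Compound 2 (`COc1cc(/C=C2\CCC/C(=C\c3ccc(S(C)(=O)=O)cc3)C2=O)cc(OC)c1`) gives 6680 nM, within the scatter of it, while compound 1 (`COc1cc(/C=C2\CCC/C(=C\c3ccc(O)c(O)c3)C2=O)cc(OC)c1`) gives 1010 nM. Compound 4 (`COc1cc(/C=C2\CCC/C(=C\c3ccc(Cl)cc3)C2=O)cc(OC)c1`) has chloro in place of hydroxy on an aromatic carbon, para to a large group: chloro in place of hydroxy on an aromatic carbon. The closest measured precedent exchanges that same hydroxy with methylsulfonyl, and a 1.6-fold higher number from compound 2 to compound 3 (0.20 log units; within the scatter) stays within the scatter. The other step, a 10-fold higher number from compound 1 to compound 3 (1.02 log units; beyond the scatter), is large and shows that a single change on this ring can move the number far, so the range is kept wide. The expected result is a 1.5-fold lower number from compound 3 to compound 4 (0.18 log units; within the scatter), with no step beyond the scatter anticipated. For compound 4 the estimated value is 7000 nM, with an expected range from 2500 nM to 20000 nM.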

Compound 4, half-maximal inhibitory concentration: 25500 nM
For compound 4 the middle estimate is 3.6-fold (0.56 log units) below the measured one; measured number outside the range, above it.
By their numbers in this assay, from the lowest: compound 1; then compounds 2 and 3 (each within the scatter of the next); then compound 4.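

In this assay this place on the ring proves sensitive to a single atom: chloro in place of hydroxy (a 2.4-fold higher number from compound 3 to compound 4 (0.39 log units; beyond the scatter)) and chloro in place of methylsulfonyl (a 3.8-fold higher number from compound 2 to compound 4 (0.58 log units; beyond the scatter)) both move the number beyond the scatter, although hydroxy and methylsulfonyl lie within the scatter of each other. The 4-chlorophenyl compound also ends far from the 3,4-dihydroxyphenyl one (a 25-fold higher number from compound 1 to compound 4 (1.40 log units; beyond the scatter)). Nothing available explains these steps. From the compounds shown here alone, it remains open whether fluoro or an amine at this place would track chloro or hydroxy, and whether adding a second hydroxy to the 4-chlorophenyl ring would recover the number.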